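Amine tail swap on the anilide series

The source may hold more compounds than are shown below. What is called first, only, known or untested is meant among the compounds shown, and "the series" means these compounds.

The three measured analogues share one core and differ at the amine end of the side chain and on the anilide. Compound 1, `CCN(CC)CCCOc1cc2ncnc(Nc3nc4ccc(C(=O)Nc5c(C)cccc5Cl)cc4s3)c2cc1OC`, gives 13200 nM in a functional assay on HCT-116 cells (Homo sapiens) for cytotoxicity, read by WST assay, with a stated time of 72 h; a lower number here means a stronger inhibitor, a higher number a weaker inhibitor. Compound 2, `COc1cc2c(Nc3nc4ccc(C(=O)Nc5c(C)cc(C)cc5C)cc4s3)ncnc2cc1OCCCN1CCCC1`, gives 5800 nM in this assay, and compound 3, `COc1cc2c(Nc3nc4ccc(C(=O)Nc5c(C)cc(C)cc5C)cc4s3)ncnc2cc1OCCCN1CCCCC1C`, gives 5600 nM in this assay. Compound 3 shows the lowest of the three numbers, though the gap to compound 2 lies within the scatter; only the gap to compound 1 is beyond it.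

Compound 4 is `CCN(CC)CCCOc1cc2ncnc(Nc3nc4ccc(C(=O)Nc5c(C)cc(C)cc5C)cc4s3)c2cc1OC`. The change from compound 3 is diethylamino in place of 2-methylpiperidin-1-yl on a saturated chain carbon, three bonds along the chain from an oxygen on an aromatic ring. Among the compounds with values here, the one measured step at this position, a 1.0-fold lower number from compound 2 to compound 3 (0.02 log units; within the scatter), moved the number hardly at all. That step exchanged two ring amines, whereas here a ring amine gives way to an open diethylamino group; compound 1 carries the same diethylamino tail but also a different anilide, so its value cannot be read as a clean comparison. The expectation is therefore a step no larger than the scatter, a 1.2-fold higher number from compound 3 to compound 4 (0.06 log units; within the scatter), with some allowance for an upward drift toward compound 1. Compound 4 is estimated at 6500 nM, with a range from 2800 nM to 15000 nM in this assay.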

Compound 4, half-maximal inhibitory concentration: 7500 nM
Estimate against measurement, compound 4: 1.2-fold (0.06 log units) below; low and high end bracket the measured number.
By their numbers in this assay, from the lowest: compounds 3, 2, 4 and 1 (each within the scatter of the next, the first and the last beyond it).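

With the 2,4,6-trimethylphenyl anilide held fixed, three amine ends can now be compared in this assay, and the open diethylamino tail reads the same as either ring amine: a 1.3-fold higher number from compound 3 to compound 4 (0.13 log units; within the scatter), and a 1.3-fold higher number from compound 2 to compound 4 (0.11 log units; within the scatter). Losing the ring from the end of the 3-carbon propyl chain, whether the ring is 2-methylpiperidin-1-yl or pyrrolidin-1-yl, therefore gives no step that can be told from repeat measurement in this small set. Within the data shown here, with the diethylamino tail fixed, the anilide can also be read on its own for the first time, and 2,4,6-trimethylphenyl in place of 2-chloro-6-methylphenyl gives a 1.8-fold lower number from compound 1 to compound 4 (0.25 log units; within the scatter); no measurement at hand bears on why these steps are this small.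

Still open, as far as these compounds go, is whether an amine end of another kind, such as morpholin-4-yl or a free primary amine, would stay within this same band of numbers, or whether a carboxylic acid in that place would depart from it. Also open is whether a shorter 2-(diethylamino)ethyl tail would hold the number, since every tail shown here ends a propyl chain.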